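One Carbon Longer on the Amide Chain

A few compounds are considered here, and "the series" means these few. Any claim that something is new, unique, unknown or untested is made for them only; others in the source may bear on it.

Of the compounds shown here, two have been measured in an assay on NIH3T3 cells for binding affinity to melatonin receptor type 1B (Homo sapiens); on this read-out lower numbers stand for stronger inhibition and higher numbers for weaker inhibition. Compound 1 `CCC(=O)NCCCc1cccc2c1C[C@@H](CCCCc1ccccc1)O2` gives 20 nM, the weaker of the two. Compound 2 `O=C(NC[C@@H]1C[C@H]1c1cccc2c1C[C@@H](CCCCc1ccccc1)O2)C1CC1` gives 5 nM, a gap beyond the usual scatter. Compound 3 `CCCC(=O)NCCCc1cccc2c1C[C@@H](CCCCc1ccccc1)O2` has not yet been measured. It differs from compound 1 in one place: methyl in place of hydrogen on a saturated chain carbon, two bonds along the chain from a carbonyl carbon. Going by the values given here, no measured pair shows a step of this kind, so any expectation for this change is only a guess. The step is expected to be small, no change at the digits printed from compound 1 to compound 3 (within the scatter). Compound 3 is therefore estimated at 20 nM, with a range from 7 nM to 60 nM.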

Compound 3, inhibition constant: 30 nM
The estimate for compound 3 lay 1.5-fold (0.18 log units) below the measured number; measured number inside the range.
By their numbers in this assay, from the lowest: compound 2; then compounds 1 and 3 (each within the scatter of the next).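

Putting methyl in place of hydrogen on a saturated chain carbon, two bonds along the chain from a carbonyl carbon, gives a 1.5-fold higher number from compound 1 to compound 3 (0.18 log units; within the scatter) in this assay. This first step of its kind shows that, at this position, the ethyl and propyl chains cannot be told apart in this assay. No outside evidence bears on this result.

On these data alone, a longer chain, or an amine or hydroxyl at this position, remains open. Compound 2 differs from compound 1 in more than one place, so it cannot settle these questions.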